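Removing a ring methyl from an inactive hydantoin-type inhibitor

A few compounds are considered here, and "the series" means these few. Any claim that something is new, unique, unknown or untested is made for them only; others in the source may bear on it.

Measured compounds:
- compound 1, `COc1ccc(-n2cnn(Cc3ccc(O)c(Br)c3)c2=O)cc1`: 5700 nM
- compound 2, `COc1ccc(N2C(=O)/C(=C/c3ccc(O)c(Br)c3)N(C)C2=O)cc1`: "not active" (no number reported)

In an assay on HeLa cells for inhibition of 17-beta-hydroxysteroid dehydrogenase type 3 (Homo sapiens) (a higher number here means a weaker inhibitor, a lower number a stronger inhibitor), compound 1 gives 5700 nM. Compound 2 gives "not active" (no number reported) in this assay, so no single number places it on the scale, and only its lack of measurable inhibition is known. Nothing links compound 1 and compound 2 by a single change, so their two values are simply set side by side.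

Compound 3, `COc1ccc(N2C(=O)N/C(=C\c3ccc(O)c(Br)c3)C2=O)cc1`, is not yet measured. It differs from compound 2 by hydrogen in place of methyl on an amide-type nitrogen in a ring. Since compound 2 has no number, no step size can be computed from it, and the direction in this assay is uncertain. The account expects that compound 3 will at best reach a weak measurable value, since compound 2 gave "not active" (no number reported), and that the more likely outcome is again a result reported without a number. Compound 3 is estimated at 15000 nM, within a range of 3000 nM to 60000 nM.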

Compound 3, half-maximal inhibitory concentration: "not active" (no number reported)
Nothing numeric was reported for compound 3; the estimate stays without a comparison.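

In this assay compound 2 and compound 3 both gave results without a number, so no step can be read between them. Nothing measured here offers an explanation for this result. The compounds shown leave open whether swapping methyl for hydrogen on the amide-type nitrogen changes inhibition at all.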